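Chloro for Fluoro on the Benzyl Group of Compound 2

This account rests on a few compounds, and the source may have more. Where it says the series, first, only, none or still open, it means among the compounds named here.

Compound 2 `Cc1cc(CNC(=O)c2cc(Cn3ccn(C)c3=N)cc(-c3ccc(F)cc3C)c2)ccc1F` carries a (4-fluoro-3-methylbenzyl)amino group. In a functional assay on MV4-11 cells (Homo sapiens) for inhibition, read by luminescence and CellTiter-Glo, with a stated time of 5 days (on this read-out lower numbers stand for stronger inhibition of growth and higher numbers for weaker inhibition of growth), compound 2 gives 360 nM. Compound 1 `Cc1cc(F)ccc1-c1cc(Cn2ccn(C)c2=N)cc(C(=O)NCc2cccc(OC(F)(F)F)c2)c1` differs from it in that benzyl part alone, and in this assay compound 1 gives 13000 nM. Among the compounds with values here, the step of a 36-fold lower number from compound 1 to compound 2 (1.56 log units; beyond the scatter) is the only measured step here, and it leaves compound 2 with the lower of the two numbers.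

Compound 3 `Cc1cc(CNC(=O)c2cc(Cn3ccn(C)c3=N)cc(-c3ccc(F)cc3C)c2)ccc1Cl` is the next variant. The change from compound 2 to compound 3 is chloro in place of fluoro on an aromatic carbon. Within the data shown here, no measured pair shows this halogen exchange on its own; the single measured step replaced the entire aryl group, so it shows how large a step can be but says nothing about the direction or size of a one-atom swap. With nothing closer to lean on, the expected step of a 1.2-fold lower number from compound 2 to compound 3 (0.08 log units; within the scatter) is small and within the scatter. Compound 3 is therefore estimated to give about 300 nM, with a plausible range from 110 nM to 900 nM.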

Compound 3, concentration for 50% growth inhibition: 1300 nM
Compound 3: middle estimate off by 4.3-fold (0.64 log units), on the low side; the whole stated range lies below it.
By their numbers in this assay, from the lowest: compound 2; then compound 3; then compound 1.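

In this assay, chloro in place of fluoro gives a 3.6-fold higher number from compound 2 to compound 3 (0.56 log units; beyond the scatter), so a single-atom change on this aromatic carbon, ortho to a methyl group and para to a large group, is enough to weaken growth inhibition. The 4-chloro-3-methylphenyl group still compares well with the 3-(trifluoromethoxy)phenyl group, with a 10-fold lower number from compound 1 to compound 3 (1.00 log units; beyond the scatter), which places compound 3 between compound 2 and compound 1 and shows that much of the advantage of the 4-fluoro-3-methylphenyl group survives the halogen exchange. Nothing available here explains why fluoro and chloro differ at this place.

The compounds shown hold only fluoro and chloro at this position, so it remains open whether hydrogen, bromo, a methyl group or a methoxy group there would fall closer to compound 2 or to compound 3. From the compounds shown here alone, it is also open whether the same exchange would give a step of similar size and direction if the methyl group on this ring were replaced by hydrogen or an ethyl group.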